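A few compounds are considered here, and "the series" means these few. Any claim that something is new, unique, unknown or untested is made for them only; others in the source may bear on it.

Series notes. Compound 1 `CC1(C)C(=O)Nc2ccc(OCc3cccc(Cl)c3)cc21` and compound 2 `O=C1Nc2ccc(OCc3cccc(Cl)c3)cc2C1=O` carry different cores; the difference between the two cores is not broken down here. Compound 3 `CC1(C)C(=O)Nc2ccc(OCc3ccc(Cl)c(Cl)c3)cc21` arises from compound 1 by the change (chloro in place of hydrogen on an aromatic carbon). Compound 4 `O=C1Nc2ccc(OCc3ccc(Cl)c(Cl)c3)cc2C1=O` arises from compound 2 by the change (chloro in place of hydrogen on an aromatic carbon). The two place descriptions agree word for word, so this is the same kind of change made on two different cores, and it occurs twice among the compounds shown.

In an assay on cells for inhibition of Amine oxidase [flavin-containing] A (Homo sapiens), read by fluorescence, with stated times of 30 min and 15 min (a lower number here means a stronger inhibitor, a higher number a weaker inhibitor), compound 1 gives > 500000 nM, which is a limit of the assay and not a number. Compound 3 in this assay likewise gives > 500000 nM, again a limit and not a number. The step that the two limits leave unreadable from compound 1 to compound 3 is therefore unreadable because of the limit of > 500000 nM in this assay, at which 2 of the 3 values shown sit. Going by the values given here, compound 2 in this assay gives 311000 nM, the only number among the three values shown, and a weak one.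

Compound 4 has not yet been measured in this assay. The expected step from compound 2 is a 1.1-fold higher number from compound 2 to compound 4 (0.05 log units; within the scatter), resting on the step that the two limits leave unreadable from compound 1 to compound 3 giving no readable size and on compound 2 giving 311000 nM. Compound 4 is accordingly expected at 350000 nM, with a range from 120000 nM to 1000000 nM, and with a real chance that the assay returns only a limit rather than a number.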

Compound 4, half-maximal inhibitory concentration: 117000 nM
For compound 4 the middle estimate is 3.0-fold (0.48 log units) above the measured one; measured number outside the range, below it.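

In this assay the added chloro, ortho to a chloro group, gives a 2.7-fold lower number from compound 2 to compound 4 (0.42 log units; beyond the scatter), so on this one core the change reads as a modest gain, although compound 4 at 117000 nM is still a weak inhibitor. The same change on the other core, from compound 1 to compound 3, cannot be read, because both compounds sit at a limit of the assay and not at a number: the limit of > 500000 nM in this assay, at which 2 of the 4 values shown sit. The series therefore holds a single readable step, which shows that the change can lower the number on one core but does not show that this carries over to the other core, since there is no second size to set against it and neither agreement nor disagreement between the cores can be claimed.

From the compounds shown here alone, whether an amine or a carboxylic acid in the place taken by the entering chloro would move the number in either direction stays open, as does the effect of a longer chain there. Also open, going by these compounds, is whether any change on the core of compound 1 brings a number rather than a limit in this assay, which is what a real comparison of the two cores would need.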